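Fluorine Added to the Ring of Compound 2

A few compounds are considered here, and "the series" means these few. Any claim that something is new, unique, unknown or untested is made for them only; others in the source may bear on it.

Of the compounds shown here, two have been measured so far, sharing one core and differing in one place. Compound 1 `Cc1cc(C)c(S(=O)(=O)N2CCC(N3CCC(C)CC3)CC2)c(C)c1` is the smaller of the two, and in a functional assay on DLD-1 cells (Homo sapiens) for antiproliferative activity, read by CellTiter-Glo, with a stated time of 72 h (a higher number here means a weaker inhibitor, a lower number a stronger inhibitor), compound 1 gives 0.03 nM. Compound 2 `Cc1cc(C)c(S(=O)(=O)N2CCC(N3CCC(Cc4ccccc4)CC3)CC2)c(C)c1` carries a phenyl in place of a hydrogen on a saturated chain carbon bound to a saturated ring carbon, and in this assay compound 2 gives 3.5 nM. The step of a 120-fold higher number from compound 1 to compound 2 (2.07 log units; beyond the scatter) is large and well beyond the scatter, so compound 2 stands highest of the two numbers, the weaker inhibitor of the pair.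

Compound 3 `Cc1cc(C)c(S(=O)(=O)N2CCC(N3CCC(Cc4ccc(F)cc4)CC3)CC2)c(C)c1` differs from compound 2 by a small change: fluoro in place of hydrogen on an aromatic carbon. For the measured compounds named here, the only measured step, phenyl in place of hydrogen, is a change of a different kind and gives no direct guide to putting a fluoro on that ring. With nothing else to draw on, the expected step of no change at the digits printed from compound 2 to compound 3 (within the scatter) is none beyond the scatter. Compound 3 is therefore estimated at 3.5 nM, with a likely range from 1.2 nM to 10 nM.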

Compound 3, half-maximal inhibitory concentration: 18 nM
Estimate against measurement, compound 3: 5.1-fold (0.71 log units) below, outside the stated range (above it).
By their numbers in this assay, from the lowest: compound 1; then compound 2; then compound 3.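

Compound 3 shows that the outer ring of the benzyl group does not tolerate every change in silence. In this assay, fluoro in place of hydrogen on an aromatic carbon, para to a large group, gives a 5.1-fold higher number from compound 2 to compound 3 (0.71 log units; beyond the scatter) and so a single added heavy atom is enough for a modest step beyond the scatter. Set against the smallest compound, the 4-fluorophenyl group gives a 600-fold higher number from compound 1 to compound 3 (2.78 log units; beyond the scatter) and the three numbers rise in order as the group at this place grows, with no compound here going against that order, though nothing measured on these compounds says why the fluoro has this effect.

As far as these compounds go, it stays open whether the rise belongs to fluoro alone or would follow any group on that aromatic carbon, such as a chloro, a methoxy or an amine, and whether fluoro on another carbon of the same ring would give a step of similar size. From the compounds shown here alone, it also stays open how a longer chain in place of the benzyl group would compare with the numbers seen so far.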